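The source may report more compounds than this note shows. Statements on the series, on what has been measured and on what is new or still open speak of the compounds shown alone.

Compound 1 `CC(=O)OCCc1c(C)[nH]c(=O)[nH]c1=O` is one of two compounds already tested in a functional assay on NCI-H460 cells (Homo sapiens) for antiproliferative activity, read by MTT assay, with a stated time of 24 h; on this read-out lower numbers stand for stronger inhibition and higher numbers for weaker inhibition. For compound 1 the result is a limit of the assay rather than a number: in this assay compound 1 gives > 100000 nM. The second compound, compound 2 `COc1nc(Cl)nc(C)c1CCOC(C)=O`, is also reported only as a limit, and in this assay compound 2 gives > 100000 nM. For the measured compounds named here, compound 1 therefore stands at the limit of > 100000 nM in this assay, at which 2 of the 2 values shown sit, with no measured step between compounds that differ in one place to draw on. Compound 3 `Cc1[nH]c(=O)[nH]c(=O)c1CCCl` has not yet been measured in this assay. It differs from compound 1 by chloro in place of acetoxy on a saturated chain carbon, two bonds along the chain from an aromatic carbon. Without any measured step to guide the size of this change, the step expected here is a number no higher from compound 1 to compound 3 (the limit leaves the size open), that is, none beyond the usual scatter. Compound 3 is thus expected to give about 100000 nM in this assay, within a range of 30000 nM to 300000 nM, and most likely again only as a limit.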

Compound 3, half-maximal inhibitory concentration: > 100000 nM
Compound 3 gave a limit, no number; the forecaster's own chance of this, stated with the estimate: 75%; the middle value lies on the limit itself.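

Compound 1 and compound 3 are both reported only as limits in this assay, and the step between them cannot be read. The compounds shown leave open whether chloro or acetoxy on the chain makes any difference to inhibition, since all sit at one limit: the limit of > 100000 nM in this assay, at which 3 of the 3 values shown sit.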